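A few compounds are considered here, and "the series" means these few. Any claim that something is new, unique, unknown or untested is made for them only; others in the source may bear on it.

Compound 1, `CNC(=O)c1cc(C(=O)NC2CC2)cn(Cc2ccc(F)cc2)c1=O`: in a physicochemical assay for solubility (a higher number here means a more soluble compound, a lower number a less soluble compound), compound 1 gives >= 162 ug/mL, which is a limit of the assay and not a number.
Compound 2, `CNC(=O)c1cc(C(=O)NC2CCC2)cn(Cc2ccccn2)c1=O`: in this assay compound 2 gives >= 103 ug/mL, also a limit.
Compound 3, `CNC(=O)c1cc(C(=O)NCCO)cn(Cc2ccccc2)c1=O`: in this assay compound 3 gives >= 140 ug/mL, again a limit.

Among the measured compounds shown here, compound 1 therefore has no fixed place among the three: its own value in this assay is a limit, and the two further values are limits as well, so no order among compounds 1, 2 and 3 can be read from them and no step between measured compounds exists in this set. The unmeasured compound 4, `CNC(=O)c1cc(C(=O)NC2CC2)cn(Cc2cccc3occc23)c1=O`, differs from compound 1 in one place: 1-benzofuran-4-yl in place of 4-fluorophenyl on a saturated chain carbon bound to an aromatic nitrogen. For the measured compounds named here, with no measured step to lean on, the size of the step from compound 1 to compound 4 rests on the change alone. The expectation is for a step downward in this assay, beyond the usual scatter, taking compound 4 out of the region where the limits sit. Compound 4 is expected to give 55 ug/mL in this assay, with a likely range from 18 ug/mL to 160 ug/mL. The step expected from compound 1 to compound 4 is an at least 2.9-fold lower number from compound 1 to compound 4 (0.46 log units; beyond the scatter).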

Compound 4, solubility: >= 110 ug/mL
Compound 4 was reported as a limit (the forecaster's own chance of this, stated with the estimate: 30%); at least 2.0-fold (0.30 log units) between middle value and limit.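

In this assay compound 4 gives >= 110 ug/mL, a limit and not a number. Among the compounds shown here, compound 1 also stands at a limit, so no step between compound 1 and compound 4 can be read. The compounds shown leave open any order among compound 1, compound 2, compound 3 and compound 4.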